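This account rests on a few compounds, and the source may have more. Where it says the series, first, only, none or still open, it means among the compounds named here.

Working notes on the series, read in a functional assay for inhibition, with Rattus norvegicus as the target; a higher number here means a weaker inhibitor, a lower number a stronger inhibitor. Compound 1 (`CC(/N=c1\c(O)c(O)\c1=N/c1ccc(C#N)cc1)C(C)(C)C`) gives 520 nM and compound 2 (`CC(C)(C)/N=c1\c(O)c(O)\c1=N/c1ccc(C#N)cc1`) gives 560 nM, and a 1.1-fold higher number from compound 1 to compound 2 (0.03 log units; within the scatter) stays within the scatter. Compound 3 (`CCC(CC)/N=c1\c(O)c(O)\c1=N/c1ccc(C#N)cc1`) has the highest number of the three, at 3340 nM. Compound 4 (`CC(C)(C)C/N=c1\c(O)c(O)\c1=N/c1ccc(C#N)cc1`) follows from neopentyl in place of pentan-3-yl on a double-bonded nitrogen, with neopentyl in place of pentan-3-yl on a double-bonded nitrogen. The nearest evidence is a 6.4-fold higher number from compound 1 to compound 3 (0.81 log units; beyond the scatter) and a 6.0-fold higher number from compound 2 to compound 3 (0.78 log units; beyond the scatter), both modest and beyond the scatter, though neither step involves neopentyl. A partial return towards compound 2 is therefore expected, and the expected change is modest, a 2.2-fold lower number from compound 3 to compound 4 (0.35 log units; beyond the scatter). The estimate for compound 4 is 1500 nM, with an expected range of 450 nM to 5000 nM.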

Compound 4, half-maximal inhibitory concentration: > 30000 nM
Compound 4: a limit, no number (the forecaster's own chance of this, stated with the estimate: 3%); middle value at least 20-fold (1.30 log units) from the limit.
By their numbers in this assay, from the lowest: compounds 1 and 2 (each within the scatter of the next); then compound 3. At a limit, above all of these: compound 4.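

In this assay compound 4 stands at a limit of the assay, not a number: the limit of > 30000 nM in this assay, at which 1 of the 4 values shown sits.

Even so, an at least 8.9-fold higher number from compound 3 to compound 4 (0.95 log units; beyond the scatter) shows that the same atoms, joined as neopentyl rather than pentan-3-yl, are not interchangeable at this place, and an at least 53-fold higher number from compound 2 to compound 4 (1.72 log units; beyond the scatter) extends this to tert-butyl. With an at least 57-fold higher number from compound 1 to compound 4 (1.76 log units; beyond the scatter), hydrogen in place of a single methyl on the chain separates the two compounds.

From the compounds shown here alone, the true size of these steps stays open past the limit. Also open, going by these compounds, is how a straight pentyl chain or a chain bearing an amine would read here.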